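From a Fluorophenyl to a Hydroxypyridine on the Shared Core

The compounds below may be only part of what the source reports. "The series", "measured", "known", "first", "only" and "open" are said of these compounds alone.

Three acids built on one core have been measured in an in vitro functional assay on HEK285-7 cells for antagonist activity at prostaglandin D2 receptor 2 (Homo sapiens), read by BRET and beta-arrestin recruitment; a higher number here means a weaker inhibitor, a lower number a stronger inhibitor. Compound 1, `O=C(O)Cc1sc(C(c2ccc(F)cc2)c2ccc(F)cc2)nc1-c1cccc(F)c1`, gives 18 nM. Compound 2, `O=C(O)Cc1sc(C(c2ccccc2)c2ccc(O)cc2)nc1-c1ccc(F)cc1`, gives 30 nM in this assay, and compound 3, `COc1ccc(C(c2ccccn2)c2nc(-c3ccc(Cl)cc3)c(CC(=O)O)s2)cc1`, gives 310 nM. Compound 1 thus holds the lowest of the three numbers, but its nearest neighbour, compound 2, sits within the usual scatter of such measurements, so these two cannot be placed in order; compound 3 alone lies clearly beyond the scatter from compound 1.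

The next compound, compound 4, `O=C(O)Cc1sc(C(c2ccc(F)cc2)c2ccc(F)cc2)nc1-c1ccnc(O)c1`, differs from compound 1 in one place: 2-hydroxypyridin-4-yl in place of 3-fluorophenyl on an aromatic carbon. Among the measured compounds shown here, no pair of measured compounds differing only in this way exists, so the size of the step cannot be read from a measured example. Compound 2 shows that a hydroxyl on one of the aromatic rings is tolerated at 30 nM, which tempers the expectation of a large loss.

The chemist expects compound 4 to give about 45 nM in this assay, within a range from 12 nM to 180 nM. This estimate means a step of a 2.5-fold higher number from compound 1 to compound 4 (0.40 log units; beyond the scatter), expected to be a modest weakening, near the edge of the scatter.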

Compound 4, half-maximal inhibitory concentration: 890 nM
Compound 4: middle estimate off by 20-fold (1.30 log units), on the low side; the measured number lies above the stated range.
By their numbers in this assay, from the lowest: compounds 1 and 2 (each within the scatter of the next); then compound 3; then compound 4.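

The change from 3-fluorophenyl to 2-hydroxypyridin-4-yl, on the aromatic carbon next to the ring nitrogen and next to the ring atom that bears a carboxymethyl group, is a large step in this assay (a 49-fold higher number from compound 1 to compound 4 (1.69 log units; beyond the scatter)). Among the compounds shown here, no earlier pair differed in only one place. For the compounds shown here, this is the first direct reading at this position, and it shows that the position is sensitive to the identity of its aromatic ring even though both groups have the same number of heavy atoms. The entering group adds a hydrogen-bond donor and acceptors where the leaving group has none, but nothing measured here links the step to these features or gives its cause.

From the compounds shown here alone, it remains open whether the step follows from the ring nitrogen, the hydroxyl or the loss of the fluorine; pyridin-4-yl, 3-hydroxyphenyl and 2-methoxypyridin-4-yl groups at this position would separate these parts. Also open, going by these compounds, is whether the step would keep its size with other groups in place of the two 4-fluorophenyl rings of compound 1.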